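Fluoro in Place of Methyl: Compound 3 to Compound 4

A few compounds are considered here, and "the series" means these few. Any claim that something is new, unique, unknown or untested is made for them only; others in the source may bear on it.

Of the compounds shown here, three have so far been measured in a functional assay on Huh-7 cells (Homo sapiens) for inhibition, read by CCK-8 assay, with a stated time of 72 h; a lower number here means a stronger inhibitor, a higher number a weaker inhibitor. Compound 1 `O=C(/C=C/c1cccnc1)NCCCc1ccc(S(=O)(=O)Nc2ccccc2)cc1` gives only a limit of the assay, > 10000 nM. Compound 2 `O=C(/C=C/c1cccnc1)NCCCCCc1cccc(S(=O)(=O)Nc2ccccc2)c1` gives 41.1 nM, while compound 3 `Cc1ccc(NS(=O)(=O)c2cccc(CCCCCCNC(=O)/C=C/c3cccnc3)c2)cc1` gives 6.92 nM. That is the lower of the two actual numbers, and the gap between them lies beyond the scatter. These compounds differ from one another in more than one place, so their values cannot be tied to any single change.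

The next compound, compound 4 `O=C(/C=C/c1cccnc1)NCCCCCCc1cccc(S(=O)(=O)Nc2ccc(F)cc2)c1`, differs from compound 3 at one site only. The change is fluoro in place of methyl on an aromatic carbon, para to a large group, which turns the 4-methylphenyl into a 4-fluorophenyl.

Going by the values given here, no measured pair here shows a swap of this kind, so what follows is an expectation only. In this assay the expected step of a 1.4-fold higher number from compound 3 to compound 4 (0.16 log units; within the scatter) is none beyond the scatter. The estimate therefore stays close to compound 3 at 6.92 nM, with a slight lean toward a higher number. Compound 4 is expected at about 10 nM, with an estimated range of 3 nM to 40 nM.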

Compound 4, half-maximal inhibitory concentration: 4.28 nM
Compound 4: middle estimate off by 2.3-fold (0.37 log units), on the high side; the range from low to high includes it.
By their numbers in this assay, from the lowest: compounds 4 and 3 (each within the scatter of the next); then compound 2. At a limit, above all of these: compound 1.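

Going by these compounds alone, the swap of 4-methylphenyl for 4-fluorophenyl gives the first comparison in this assay in which a single site changes, and the step is a 1.6-fold lower number from compound 3 to compound 4 (0.21 log units; within the scatter) with the rest of the molecule held constant. Within the data shown here, this pair therefore shows that, at this position on the aromatic ring and with this hexyl-linked compound, fluoro and methyl cannot be told apart in the assay, a point that the earlier compounds could not settle because each differed from the others in more than one place. The data shown offer no measured basis for explaining this result, and nothing here can assign a cause to it.

From the compounds shown here alone, this is one pair, so it says nothing yet about how a hydrogen, a trifluoromethyl, an amine or a carboxylic acid at the same position would read, and whether the site accepts such groups as readily remains open. The effects of chain length and of where the chain sits on the ring also remain unresolved, since no pair among the compounds shown isolates either one.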